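This account rests on a few compounds, and the source may have more. Where it says the series, first, only, none or still open, it means among the compounds named here.

Of the compounds shown here, three built on one shared core have so far been tested in a functional assay on the whole organism with Rattus norvegicus as the target; a higher number here means that more compound is needed for the effect, a lower number that less compound is needed. Compound 1 `CC(C)(C)Oc1ccc2nc(N)sc2c1` gives only a limit of the assay there, > 10 mg/kg. Compound 2 `Nc1nc2cccc(OC(F)(F)F)c2s1` likewise reaches only a limit, > 10 mg/kg. Compound 3 `COC(=O)Cn1c(=N)sc2cc(OC(F)(F)F)ccc21` also stands at a limit, > 10 mg/kg. The picture is summed up by the limit of > 10 mg/kg in this assay, at which 3 of the 3 values shown sit: none of the three has yet produced a number in this assay, so compound 3 simply sits at the same limit as the other two, neither stronger nor weaker on the evidence available.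

Compound 4 `N=c1sc2cc(OC(F)(F)F)ccc2n1CCSc1ccccc1` has not been measured. It differs from compound 3 in a single place: (phenylsulfanyl)methyl in place of methoxycarbonyl on a saturated chain carbon bound to an aromatic nitrogen. For the measured compounds named here, no step between two measured compounds exists, so the size of the change from compound 3 to compound 4 in this assay cannot be read from the data, and the shared limit in the limit of > 10 mg/kg in this assay, at which 3 of the 3 values shown sit, offers no hint of direction. Compound 4 is therefore expected to stay near that limit, at an estimated 15 mg/kg with a range from 3 mg/kg to 60 mg/kg. The estimated step that the limit leaves unreadable from compound 3 to compound 4 is expected to be no larger than the scatter.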

Compound 4, dose for half-maximal effect: 4.5 mg/kg
Compound 4: middle estimate off by 3.3-fold (0.52 log units), on the high side; the measured number falls inside the stated range.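

In this assay, exchanging the methoxycarbonyl group for (phenylsulfanyl)methyl gives an at least 2.2-fold lower number from compound 3 to compound 4 (0.34 log units; beyond the scatter), which shows that a change at this one place can bring a measurable effect in the whole animal. From the compounds shown here alone, the value for compound 3 is only a limit, so this step is a minimum and its full size remains unknown. Compound 4 is the only one of the four to give a true number rather than a limit: the limit of > 10 mg/kg in this assay, at which 3 of the 4 values shown sit.

Going by these compounds, it remains open whether the effect needs the sulfur, as against an oxygen in its place, or the phenyl ring, as against a cyclohexyl ring or a plain butyl chain. Compound 1 and compound 2 differ from compound 4 in more than one place, so they cannot settle this.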